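The compounds below may be only part of what the source reports. "The series", "measured", "known", "first", "only" and "open" are said of these compounds alone.

Compound 1 `COc1cc(/C=C/C(=O)/C=C/c2ccco2)ccc1OCc1cn(CCCOc2cc(=O)oc3ccccc23)nn1`: 51%
Compound 2 `COc1ccccc1/C=C/C(=O)/C=C/c1ccc(OCc2cn(CCCOc3cc(=O)oc4ccccc34)nn2)c(OC)c1`: 53%
Compound 3 `COc1cc(/C=C/C(=O)/C=C/c2ccco2)ccc1OCc1cn(CCCCOc2cc(=O)oc3ccccc23)nn1`: 47%

These three compounds were tested in a functional assay on HCT-116 cells (Homo sapiens) for inhibition, read by sulforhodamine B assay, with a stated time of 48 h, tested at 50 uM (on this read-out higher numbers stand for more inhibition of growth at the one concentration tested and lower numbers for less inhibition of growth), and the three values lie within the scatter of one another. Compound 2 differs from compound 1 by 2-methoxyphenyl in place of furan-2-yl on a double-bonded chain carbon bound to a double-bonded chain carbon, a change that gave a number 2 percentage points higher from compound 1 to compound 2 (within the scatter). Compound 4 `COc1ccccc1/C=C/C(=O)/C=C/c1ccc(OCc2cn(CCCCOc3cc(=O)oc4ccccc34)nn2)c(OC)c1` has not yet been measured in this assay. It differs from compound 3 by 2-methoxyphenyl in place of furan-2-yl on a double-bonded chain carbon bound to a double-bonded chain carbon, the same change at the same place as before. How the core of compound 3 differs from the core of compound 1 is not broken down here. Because the earlier step came out as a number 2 percentage points higher from compound 1 to compound 2 (within the scatter), the step from compound 3 to compound 4 is expected to be a number 2 percentage points higher from compound 3 to compound 4 (within the scatter). Compound 4 is therefore estimated to give 49% in this assay, most likely between 38% and 60%.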

Compound 4, percent growth inhibition at one concentration: 43%
Estimate against measurement, compound 4: 6 percentage points above; the range from low to high includes it.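

In this assay, 2-methoxyphenyl in place of furan-2-yl gave a number 4 percentage points lower from compound 3 to compound 4 (within the scatter). Set beside the earlier step, the change shows no difference between the two cores that can be told apart: the same change on two cores in this assay, a number 2 percentage points higher (within the scatter) from compound 1 to compound 2 and a number 4 percentage points lower (within the scatter) from compound 3 to compound 4, 6 percentage points apart, within the scatter of two such steps. This does not show that the change has an effect on either core, or that the two cores would respond alike to a change with a larger step, as both steps are small and each rests on a single concentration.

The compounds shown leave open what an amine or a carboxylic acid would do in place of furan-2-yl. They also leave open what a longer chain would do in the core.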